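The compounds below may be only part of what the source reports. "The series", "measured", "known", "first", "only" and "open" are said of these compounds alone.

Compound 1 `COC(=O)/C=C\NC(=O)[C@H](O)C(C)(C)CO` belongs to a small set of open-chain hydroxy amides that share one core and differ in the ester alkyl group and in the drawn configuration. In an ADME assay on HEK293 cells (Homo sapiens) for inhibition, read by CellTiter-Glo, with a stated time of 96 h, tested at 100 uM (a lower number here means less inhibition, a higher number more inhibition at the concentration tested (going by the name of the read-out)), compound 1 stands at "not determined" (no result reported), so no number places it on the scale. The neighbours give a sense of where the series sits. Compound 2 `CCOC(=O)/C=C/NC(=O)[C@H](O)C(C)(C)CO` gives -5% in this assay, and compound 3 `COC(=O)/C=C/NC(=O)[C@@H](O)C(C)(C)CO` gives -2%. These two values lie within the usual scatter of each other, so no order can be read between them. Compound 1 and compound 3 are related because of the fact that compounds 1 and 3 differ only in the configuration as drawn, and nothing more is known about what that difference does here.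

Compound 4 `CCOC(=O)/C=C\NC(=O)[C@H](O)C(C)(C)CO` is the next compound to be measured. It differs from compound 1 in one place: methyl in place of hydrogen on a saturated chain carbon bound to an oxygen next to a carbonyl group. For this assay, compound 4 is expected to show no change beyond the scatter in either direction, since compound 2 carries the same ethyl ester and gives -5%. Compound 4 is therefore estimated at -3%, with a range from -15% to 10%.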

Compound 4, a percentage reported as inhibition, at one concentration (the size of the read-out at that concentration, not a potency): -6%
Estimate against measurement, compound 4: 3 percentage points above, and the stated range covers the measured number.
By their numbers in this assay, from the lowest: compounds 4, 2 and 3 (each within the scatter of the next).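

In this assay, within the data shown here, compound 4 gives the first number for a double bond drawn Z in this set, and the step reads a number 1 percentage points lower from compound 2 to compound 4 (within the scatter). The two ethyl esters therefore show no separation by the drawn geometry of the double bond at this concentration, and this pair isolates that single difference: the fact that compounds 2 and 4 differ only in the configuration as drawn The change from methoxycarbonyl to ethoxycarbonyl itself cannot be read, as compound 1 has no number to set against compound 4.

The compounds shown leave open whether a different group at this place, such as a carboxylic acid or a longer chain, would give a number in this assay that stands clear of the scatter. Among these compounds, they also leave open what the configuration at the hydroxy-bearing carbon does on its own, since no pair with two numbers isolates it.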